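Swapping Chloro for Methoxy on Two Related Cores

This account rests on a few compounds, and the source may have more. Where it says the series, first, only, none or still open, it means among the compounds named here.

Of the compounds shown here, three have been measured in a functional assay on MIA PaCa-2 cells (Homo sapiens) for antiproliferative activity, read by WST assay, with a stated time of 72 h; on this read-out higher numbers stand for weaker inhibition and lower numbers for stronger inhibition. Compound 1 `COc1ccc2[nH]c(-c3nc(-c4ccccc4)no3)cc2c1` gives 32600 nM, and compound 2 `Clc1ccc2[nH]c(-c3nc(-c4ccccc4)no3)cc2c1` gives 23100 nM. Between them lies one change, (methoxy in place of chloro on an aromatic carbon), which made a 1.4-fold higher number from compound 2 to compound 1 (0.15 log units; within the scatter). Compound 3 `Clc1ccc(-c2noc(-c3cc4ccccc4[nH]3)n2)cc1` gives 19200 nM in this assay; the difference between the core of compound 3 and that of compound 2 is not broken down here. Compound 4 `COc1ccc(-c2noc(-c3cc4ccccc4[nH]3)n2)cc1` is not yet measured. Within the data shown here, it differs from compound 3 by methoxy in place of chloro on an aromatic carbon, the same kind of change as the one from compound 2 to compound 1, though here the group sits para to a large group rather than on a ring that is part of a fused or bridged system of two rings. Because the earlier change gave a 1.4-fold higher number from compound 2 to compound 1 (0.15 log units; within the scatter), compound 4 is expected to show a step of a 1.3-fold higher number from compound 3 to compound 4 (0.11 log units; within the scatter) in this assay. Compound 4 is therefore estimated at 25000 nM, most likely between 12000 nM and 50000 nM.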

Compound 4, half-maximal inhibitory concentration: > 50000 nM
Compound 4: only a limit was reported; the forecaster's own chance of this, stated with the estimate: 10%; middle value at least 2.0-fold (0.30 log units) away from the limit.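

In this assay, methoxy in place of chloro on an aromatic carbon gave an at least 2.6-fold higher number from compound 3 to compound 4 (0.41 log units; beyond the scatter), a step beyond the scatter, whereas the same change on the other core gave a 1.4-fold higher number from compound 2 to compound 1 (0.15 log units; within the scatter), a step within it. From the compounds shown here alone, compound 4 has only a limit of > 50000 nM, not a number, so the full size of its step remains unknown. This does not establish whether the change carries over unaltered from one core to the other: the same change on two cores in this assay, a 1.4-fold higher number (0.15 log units; within the scatter) from compound 2 to compound 1 and an at least 2.6-fold higher number (0.41 log units; beyond the scatter) from compound 3 to compound 4; the limit leaves it open whether they differ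

The compounds shown leave open how an amine, a carboxylic acid or a longer alkoxy chain in place of the chloro would read out. They also leave open how the change from chloro to methoxy would behave on any third core.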